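Replacing the Halogenated Ring of Compound 2

The source may report more compounds than this note shows. Statements on the series, on what has been measured and on what is new or still open speak of the compounds shown alone.

Among the compounds with values here, in a functional assay on K562 cells (Homo sapiens) for antiproliferative activity, with a stated time of 72 h (on this read-out lower numbers stand for stronger inhibition and higher numbers for weaker inhibition), compound 2 (`OC[C@H]1O[C@@H](n2cnc3c(NCc4ccc(F)cc4Cl)ncnc32)[C@H](O)[C@@H]1O`) gives 15600 nM, the only exact number so far. Compound 1 (`COc1cccc(CNc2ncnc3c2ncn3[C@@H]2O[C@H](CO)[C@@H](O)[C@H]2O)c1OC`) gives > 166000 nM, which is a limit of the assay. Compound 3 (`Cc1cccc(CNc2ncnc3c2ncn3[C@@H]2O[C@H](CO)[C@@H](O)[C@H]2O)c1O`) changes compound 2 on a saturated chain carbon bound to a nitrogen on an aromatic ring: 2-hydroxy-3-methylphenyl in place of 2-chloro-4-fluorophenyl on a saturated chain carbon bound to a nitrogen on an aromatic ring. Within the data shown here, the one measured step that bears on this, an at least 10-fold lower number from compound 1 to compound 2 (1.02 log units; beyond the scatter), is large and brought in the same 2-chloro-4-fluorophenyl that now leaves. A moderate move toward weaker inhibition is therefore expected, namely a 2.9-fold higher number from compound 2 to compound 3 (0.46 log units; beyond the scatter). Compound 3 is estimated at 45000 nM, with an expected range of 12000 nM to 166000 nM.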

Compound 3, half-maximal inhibitory concentration: 18000 nM
Estimate against measurement, compound 3: 2.5-fold (0.40 log units) above; the measured number falls inside the stated range.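

In this assay, putting 2-hydroxy-3-methylphenyl in place of the halogenated ring gives a 1.2-fold higher number from compound 2 to compound 3 (0.06 log units; within the scatter), so at this position neither chlorine nor fluorine is required to keep the measured activity. The same ring in place of 2,3-dimethoxyphenyl gives an at least 9.2-fold lower number from compound 1 to compound 3 (0.96 log units; beyond the scatter), so two quite different rings now stand apart from the dimethoxy ring. The value of compound 1 is a limit, so the true size of that step stays unknown: the limit of > 166000 nM in this assay, at which 1 of the 3 values shown sits.

The compounds shown leave open whether the hydroxy or the methyl group alone would match this result. They also leave open how a ring carrying an amine or a carboxylic acid would compare.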